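The compounds below may be only part of what the source reports. "The series", "measured", "known", "first", "only" and "open" are said of these compounds alone.

In an ADME assay on microsomes from liver (Homo sapiens) for metabolic stability, read by LC-MS, tested at 1 uM (a higher number here means faster removal of the compound, a lower number slower removal), compound 3 `NC(=O)C1CCN(Cc2ccc([C@H]3CC[C@]4(CC3)OOC3(O4)C4CC5CC(C4)CC3C5)cc2)CC1` gives 10 mL.min-1.g-1, level with compound 2 `c1cc([C@H]2CC[C@]3(CC2)OOC2(O3)C3CC4CC(C3)CC2C4)ccc1OCCCNC1CCOCC1` at 10 mL.min-1.g-1 at the digits shown, while compound 1 `O=S(=O)(c1ccc([C@H]2CC[C@]3(CC2)OOC2(O3)C3CC4CC(C3)CC2C4)cc1)N1CCNCC1` gives 16 mL.min-1.g-1, within the scatter of both. Compound 4 `CC(C)(O)CNCCCOc1ccc([C@H]2CC[C@]3(CC2)OOC2(O3)C3CC4CC(C3)CC2C4)cc1` carries 3-((2-hydroxy-2-methylpropyl)amino)propoxy in place of (4-carbamoylpiperidin-1-yl)methyl, on an aromatic carbon para to a large group: 3-((2-hydroxy-2-methylpropyl)amino)propoxy in place of (4-carbamoylpiperidin-1-yl)methyl on an aromatic carbon.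

Three measured exchanges at this aromatic carbon bear on the change. The closest is the exchange between 3-((oxan-4-yl)amino)propoxy and (4-carbamoylpiperidin-1-yl)methyl, which gave no change at the digits printed from compound 2 to compound 3 (within the scatter). The exchanges starting from (piperazin-1-yl)sulfonyl gave a 1.6-fold lower number from compound 1 to compound 2 (0.20 log units; within the scatter) and a 1.6-fold lower number from compound 1 to compound 3 (0.20 log units; within the scatter). All three lie within the scatter. Within the data shown here, no measured pair tests the 2-hydroxy-2-methylpropyl group itself, so this evidence is indirect and rests on only three compounds.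

No step beyond the scatter is therefore expected in this assay, and no direction is favoured. The expected step is no change at the digits printed from compound 3 to compound 4 (within the scatter). For compound 4 the estimated value is 10 mL.min-1.g-1, with an expected range of 5 mL.min-1.g-1 to 21 mL.min-1.g-1.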

Compound 4, intrinsic clearance in microsomes: 8 mL.min-1.g-1
Compound 4: the middle estimate sits 1.3-fold (0.10 log units) above what was measured; the range from low to high includes it.
By their numbers in this assay, from the lowest: compounds 4, 2, 3 and 1 (each within the scatter of the next).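

In this assay, the first direct test of 2-hydroxy-2-methylpropyl on the amine nitrogen gives a 1.3-fold lower number from compound 2 to compound 4 (0.10 log units; within the scatter), so this group stands in place of oxan-4-yl with no step beyond the scatter. The 3-((2-hydroxy-2-methylpropyl)amino)propoxy group, which has no ring, also stays within the scatter against the ring-bearing (4-carbamoylpiperidin-1-yl)methyl, with a 1.3-fold lower number from compound 3 to compound 4 (0.10 log units; within the scatter), and against (piperazin-1-yl)sulfonyl, with a 2.0-fold lower number from compound 1 to compound 4 (0.30 log units; within the scatter). Nothing shown here bears on a cause for these steps.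

All the steps among these four compounds lie within the scatter, so no change at this aromatic carbon is yet known to move intrinsic clearance beyond it. As far as these compounds go, whether a carboxylic acid in place of the hydroxyl, or a chain longer than propoxy, would do so remains open.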